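Vinyl-to-methyl step in a nitrile-bearing acetophenone series

The source may report more compounds than this note shows. Statements on the series, on what has been measured and on what is new or still open speak of the compounds shown alone.

Measured so far:
compound 1 `CCc1cc(C(C)=O)c(O)cc1OCCCCCCC#N`; in an assay on isolated protein for inhibition of leukotriene B4 receptor 1 (Homo sapiens), tested at 10 uM (on this read-out higher numbers stand for more inhibition at the one concentration tested (going by the name of the read-out) and lower numbers for less inhibition), compound 1 gives 103%
compound 2 `C=CCc1cc(C(C)=O)c(O)cc1OCCCCCCC#N`; compound 2 gives 97%
compound 3 `C=CCc1cc(C(C)=O)c(O)cc1OCc1cccc(C#N)c1`; compound 3 gives 71%

Compound 1 and compound 2 share one core; compound 3 and the not yet measured compound 4 `CCc1cc(C(C)=O)c(O)cc1OCc1cccc(C#N)c1` share another. The difference between the two cores is not broken down here. Within the first pair, the change from compound 2 to compound 1 is methyl in place of vinyl on a saturated chain carbon bound to an aromatic carbon and it produced a number 6 percentage points higher from compound 2 to compound 1 (within the scatter), so the two values are within the scatter of each other and no order between compound 1 and compound 2 is claimed. Compound 3 stands lowest of the three measured numbers, with its distance to compound 2 and to compound 1 both beyond the scatter.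

The change from compound 3 to compound 4 is methyl in place of vinyl on a saturated chain carbon bound to an aromatic carbon. Its place reads word for word as in the first pair, so this is the same change made on the second core. For compound 4 a step of about a number 5 percentage points higher from compound 3 to compound 4 (within the scatter) is expected; this rests on the step of a number 6 percentage points higher from compound 2 to compound 1 (within the scatter), which lay within the scatter. Within the data shown here, only one earlier instance exists and it sits on a different core, where the starting number was already high in this assay, so the range for compound 4 is kept wide. Compound 4 is estimated at 76%, between 58% and 92%.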

Compound 4, a percentage reported as inhibition, at one concentration (the size of the read-out at that concentration, not a potency): 58%
Compound 4: middle estimate off by 18 percentage points, on the high side, and the stated range covers the measured number.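

In this assay, methyl in place of vinyl gives a number 13 percentage points lower from compound 3 to compound 4 (beyond the scatter) on the core shared by these two compounds, and set beside the earlier pair, the same change does not give the same outcome on both cores: the same change on two cores in this assay, a number 6 percentage points higher (within the scatter) from compound 2 to compound 1 and a number 13 percentage points lower (beyond the scatter) from compound 3 to compound 4, 19 percentage points apart, beyond the scatter of two such steps

The step seen on the core of compound 1 therefore cannot be carried over as a fixed increment to the core of compound 3; in these two pairs, the outcome of the change differs with the core on which it is made. Among these compounds, this does not show which part of the cores is responsible for the gap, nor how the change would behave on a third core, and with only one pair per core and one tested concentration it gives no measure of potency.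

The compounds shown leave open whether a propyl group at the same place would follow the allyl or the ethyl compounds on either core. Also open, from the compounds shown here alone, is how either core would respond if a carboxylic acid or an amine took the place of the nitrile, or if a longer chain carried the nitrile on the core of compound 1.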